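The source may hold more compounds than are shown below. What is called first, only, known or untested is meant among the compounds shown, and "the series" means these compounds.

Measured so far in an assay on isolated protein for inhibition of Fatty-acid amide hydrolase 1 (Homo sapiens); a higher number here means a weaker inhibitor, a lower number a stronger inhibitor:
- compound 1, `Cc1cccc(CN2CCC(CCCC(=O)c3ncco3)CC2)c1`, gives 90 nM
- compound 2, `Cc1ccc(CN2CCC(CCCC(=O)c3ncco3)CC2)cc1`, gives 400 nM

Compound 2 stands at the higher of the two numbers in this assay; the step of a 4.4-fold higher number from compound 1 to compound 2 (0.65 log units; beyond the scatter) separates it from compound 1 and lies beyond the scatter.

Compound 3, `COc1cccc(CN2CCC(CCCC(=O)c3ncco3)CC2)c1`, is not yet measured. It differs from compound 2 in one place: 3-methoxyphenyl in place of 4-methylphenyl on a saturated chain carbon bound to an amine nitrogen in a ring.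

Among the measured compounds shown here, the only measured step that bears on this change is a 4.4-fold higher number from compound 1 to compound 2 (0.65 log units; beyond the scatter), in which 3-methylphenyl was exchanged for 4-methylphenyl on the same saturated chain carbon bound to the ring amine nitrogen. For the measured compounds named here, the change to compound 3 returns to a 3-substituted phenyl, as in compound 1, but with methoxy rather than methyl, for which no measured step exists. The expectation is therefore a lower number, of a size comparable to the step already seen in this series, as a 3.3-fold lower number from compound 2 to compound 3 (0.52 log units; beyond the scatter), with the methoxy-for-methyl exchange left as the open uncertainty.

Compound 3 is estimated at 120 nM in this assay, with a range from 40 nM to 400 nM.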

Compound 3, half-maximal inhibitory concentration: 34 nM
Estimate against measurement, compound 3: 3.5-fold (0.55 log units) above; the measured number lies below the stated range.
By their numbers in this assay, from the lowest: compound 3; then compound 1; then compound 2.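

In this assay, compound 3 is the strongest inhibitor of the three, and 3-methoxyphenyl in place of 4-methylphenyl on the saturated chain carbon bound to the ring amine nitrogen gives a 12-fold lower number from compound 2 to compound 3 (1.07 log units; beyond the scatter). The comparison of the two 3-substituted phenyl groups gives a 2.6-fold lower number from compound 1 to compound 3 (0.42 log units; beyond the scatter), which shows that the identity of the substituent also moves the number at this position, something the pair of methylphenyl compounds could not show. Nothing available accounts for the gain from methoxy in place of methyl.

On these data alone, whether 4-methoxyphenyl would stand as far above 3-methoxyphenyl as 4-methylphenyl stands above 3-methylphenyl remains open, so the large step from the methylphenyl group to the methoxyphenyl group cannot yet be split into a contribution from where the group sits and one from what the group is. Also open, as far as these compounds go, is how far the trend with 3-substituents extends, for example to 3-ethoxyphenyl, 3-chlorophenyl or 3-hydroxyphenyl, and where plain phenyl would fall as a reference for all of them.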